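From hydroxy to bromo on the aromatic ring

The source may report more compounds than this note shows. Statements on the series, on what has been measured and on what is new or still open speak of the compounds shown alone.

Compound 1 (`COC(=O)C1=C(C)N=C(C)/C(=C(\O)OC)C1c1c(F)c(F)c(F)c(F)c1F`): 4.37 nM
Compound 2 (`COC(=O)C1=C(C)N=C(C)/C(=C(\O)OC)C1c1cccc(O)c1`): 1000 nM
Compound 3 (`COC(=O)C1=C(C)N=C(C)/C(=C(\O)OC)C1c1cc(OC)c(OC)cc1OC`): 1000000 nM

In a functional assay (muscle tissue) with Cavia porcellus as the target (on this read-out lower numbers stand for an effect already at smaller amounts and higher numbers for an effect only at larger amounts of compound), compound 2 (1000 nM) holds the second highest of the three numbers. Its value lies far above that of compound 1 (4.37 nM) and far below that of compound 3 (1000000 nM), and both gaps are beyond the usual scatter.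

Compound 4 (`COC(=O)C1=C(C)N=C(C)/C(=C(\O)OC)C1c1cccc(Br)c1`) differs from compound 2 in one place, with bromo in place of hydroxy on an aromatic carbon, the change from 3-hydroxyphenyl to 3-bromophenyl (bromo in place of hydroxy on an aromatic carbon). Within the data shown here, no measured pair shows this change on its own, so any expectation remains loose. Among the measured compounds shown here, compound 1 (4.37 nM) is the only measured compound with halogen on its aromatic ring, and on that single comparison a move to a lower number is expected in this assay for the new compound. The estimated step of a 33-fold lower number from compound 2 to compound 4 (1.52 log units; beyond the scatter) is expected to lie beyond the scatter. For compound 4 the expected value is 30 nM with 5 nM to 200 nM as the estimated range.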

Compound 4, half-maximal effective concentration: 1.29 nM
Estimate against measurement, compound 4: 23-fold (1.37 log units) above, and the stated range ends above it.
By their numbers in this assay, from the lowest: compound 4; then compound 1; then compound 2; then compound 3.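

In this assay, among these compounds, the exchange of hydroxy for bromo on this aromatic carbon, meta to a large group, gives a 780-fold lower number from compound 2 to compound 4 (2.89 log units; beyond the scatter) and so provides the first comparison here in which only one place differs. The earlier compounds shown here differ from one another in several places on the ring, so they could not show that this single position, with the shared core unchanged, can by itself produce a large step well beyond the scatter. The change takes away a hydroxy group with its hydrogen-bond donor and acceptor and puts in a bromine atom, but nothing available explains the size of the step.

The compounds shown leave open whether the step comes from gaining bromo or from losing hydroxy. They also leave open how chloro, an amine or a carboxylic acid would read out on the same aromatic carbon.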